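A Bromohydroxyphenyl Amide Stripped Down to Plain Phenyl

The source may report more compounds than this note shows. Statements on the series, on what has been measured and on what is new or still open speak of the compounds shown alone.

Compound 2 `O=C(Nc1ccc(Sc2nc3ccccc3s2)c(Cl)c1)c1cccc(Br)c1O` was examined in an assay on isolated protein for inhibition of thiosulfate sulfurtransferase (Homo sapiens), with a stated time of 60 min, in the absence of a further agent; a lower number here means a stronger inhibitor, a higher number a weaker inhibitor. In this assay compound 2 gives > 100000 nM, which is a limit of the assay and not a number. Compound 1 `COc1c(Br)cccc1C(=O)Nc1ccccc1` likewise gives only a limit in this assay, namely > 100000 nM. Compound 3 `COc1ccc(Br)cc1C(=O)Nc1ccccc1` gives > 100000 nM in this assay, again a limit. Compound 2 thus stands exactly where the other two values stand, at the limit of > 100000 nM in this assay, at which 3 of the 3 values shown sit, and no measured value sets any of these compounds apart from another.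

Compound 4 `O=C(Nc1ccc(Sc2nc3ccccc3s2)c(Cl)c1)c1ccccc1` has not yet been measured. It differs from compound 2 in one place: phenyl in place of 3-bromo-2-hydroxyphenyl on a carbonyl carbon. Within the data shown here, no measured pair differing in one place exists here, so the size of this step cannot be read from measured compounds. Since compound 2 sits at the limit of > 100000 nM in this assay, at which 3 of the 3 values shown sit, the step is expected to stay within the scatter: a number no higher from compound 2 to compound 4 (the limit leaves the size open). Compound 4 is therefore estimated at 100000 nM in this assay, with a range from 30000 nM to 300000 nM, and it is expected that only a limit will again be reported.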

Compound 4, half-maximal inhibitory concentration: > 100000 nM
Compound 4: only a limit was reported (the forecaster's own chance of this, stated with the estimate: 85%); the middle value sits exactly at the limit.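

Among these compounds, compound 2 and compound 4 both give only a limit, so no step between them can be read. The compounds shown leave open whether phenyl or 3-bromo-2-hydroxyphenyl on the carbonyl carbon makes any difference, and what would give a measurable value in this assay.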